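Cytotoxicity notes on a shared-core series

The source may report more compounds than this note shows. Statements on the series, on what has been measured and on what is new or still open speak of the compounds shown alone.

Measured so far in an ADME assay on U2OS cells (Homo sapiens) for cytotoxicity; a lower number here means that less compound is tolerated, a higher number that more compound is tolerated:
compound 1 `CCSc1ccc(-c2nccc3[nH]c(C(C)(C)O)cc23)cc1` gives 17200 nM
compound 2 `CC(C)(O)c1cc2c(-c3ccsc3)nccc2[nH]1` gives 199000 nM
compound 3 `COc1ccccc1-c1nccc2[nH]c(C(C)(C)O)cc12` gives "not determined" (no result reported), so no number is available for it

Compound 1 stands as the lowest of the two numbers available; compound 2 sits at a markedly higher value, and this gap lies beyond the usual scatter. Compound 3 contributes no figure to the comparison.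

The next compound, compound 4 `CC(C)(C)c1ccc(-c2nccc3[nH]c(C(C)(C)O)cc23)cc1`, differs from compound 1 in one place: tert-butyl in place of ethylsulfanyl on an aromatic carbon. Going by the values given here, no measured pair with this same change exists, so the size of the step is open. The expectation is a step no larger than the scatter, in either direction, with the estimated step being a 1.2-fold higher number from compound 1 to compound 4 (0.07 log units; within the scatter). Compound 4 is accordingly expected at 20000 nM, within a range from 7000 nM to 60000 nM.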

Compound 4, half-maximal cytotoxic concentration: 35300 nM
The estimate for compound 4 lay 1.8-fold (0.25 log units) below the measured number; the range from low to high includes it.
By their numbers in this assay, from the lowest: compound 1; then compound 4; then compound 2.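

In this assay, the aromatic carbon para to a large group now has its first measured change. Tert-butyl in place of ethylsulfanyl gives a 2.1-fold higher number from compound 1 to compound 4 (0.31 log units; beyond the scatter) and so the step is modest but beyond the scatter, showing that this position is not indifferent to the exchange. No supporting data bear on the reason for this step.

On these data alone, whether the sulfur or the branching of tert-butyl matters more remains open. Isopropyl, an amine or a carboxylic acid at this position would show how far the trend extends.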